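Trimming Isopropyl to Ethyl on a Weak Core

A few compounds are considered here, and "the series" means these few. Any claim that something is new, unique, unknown or untested is made for them only; others in the source may bear on it.

In a functional assay for inhibition, with Homo sapiens as the target (a lower number here means a stronger inhibitor, a higher number a weaker inhibitor), compound 1 `CCCc1nc(C)c2ccnc(Nc3cc[nH]n3)n12` gives 25000 nM. Compound 2 `CCCc1cnc(Nc2cc[nH]n2)n2c(CCC)nc(C)c12` reaches only a limit in this assay, > 48000 nM. Compound 3 `CCCc1nc(C)c2c(C(C)C)cnc(Nc3cc[nH]n3)n12` likewise reaches only a limit, > 48000 nM. The weak end of the set is marked by the limit of > 48000 nM in this assay, at which 2 of the 3 values shown sit. Compound 4 `CCCc1nc(C)c2c(CC)cnc(Nc3cc[nH]n3)n12` differs from compound 3 by hydrogen in place of methyl on a saturated chain carbon bound to an aromatic carbon and a saturated chain carbon. The measured steps that bear on this are an at least 1.9-fold higher number from compound 1 to compound 3 (0.28 log units; that floor lies within the scatter), an at least 1.9-fold higher number from compound 1 to compound 2 (0.28 log units; that floor lies within the scatter) and a step that the two limits leave unreadable from compound 2 to compound 3, so the direction of a move away from hydrogen is at best faintly read. An ethyl on that carbon is therefore expected to leave compound 4 weak, with the step of an at least 1.2-fold lower number from compound 3 to compound 4 (0.07 log units; that floor lies within the scatter) estimated to stay unreadable against the limit. The estimate for compound 4 is 40000 nM, within 15000 nM to 150000 nM.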

Compound 4, half-maximal inhibitory concentration: > 48000 nM
Compound 4: a limit, no number; the forecaster's own chance of this, stated with the estimate: 55%; middle value at least 1.2-fold (0.07 log units) away from the limit.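

In this assay compound 4 stays at a limit, so trimming isopropyl to ethyl brings no measurable return, and its steps to compound 2 and compound 3 cannot be read. Against hydrogen on the aromatic carbon, ethyl gives an at least 1.9-fold higher number from compound 1 to compound 4 (0.28 log units; that floor lies within the scatter). The weak end of the set now takes in ethyl as well: the limit of > 48000 nM in this assay, at which 3 of the 4 values shown sit.

On these data alone, whether methyl, an amine or a carboxylic acid on that aromatic carbon would match or better compound 1 remains open. So does how far compound 2, compound 3 and compound 4 differ from one another.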